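Swapping fluoro for methyl in a small antiproliferative series

This account rests on a few compounds, and the source may have more. Where it says the series, first, only, none or still open, it means among the compounds named here.

Compound 1 `COc1cc(C(=O)c2sc(-c3ccc([N+](=O)[O-])cc3)cc2N)cc(OC)c1OC` and compound 2 `COc1cc(C(=O)c2sc(-c3ccc(F)cc3)cc2N)cc(OC)c1OC` have the same core and differ in one group. In a functional assay on CCRF-CEM cells (Homo sapiens) for antiproliferative activity (on this read-out higher numbers stand for weaker inhibition and lower numbers for stronger inhibition), compound 1 gives 99 nM, while compound 2 gives 15 nM, the lower and therefore stronger of the two numbers. Fluoro in place of nitro on an aromatic carbon accounts for the whole difference between them: a 6.6-fold lower number from compound 1 to compound 2 (0.82 log units; beyond the scatter), a modest step beyond the scatter.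

The next compound, compound 3 `COc1cc(C(=O)c2sc(-c3ccc(C)cc3)cc2N)cc(OC)c1OC`, has methyl in place of fluoro on an aromatic carbon, so that 4-fluorophenyl becomes 4-methylphenyl: methyl in place of fluoro on an aromatic carbon. Among the measured compounds shown here, the one measured step at this place, a 6.6-fold lower number from compound 1 to compound 2 (0.82 log units; beyond the scatter), shows that the number can move when the group there changes, yet neither group in that step is methyl. A single step of this kind fixes no direction for the new change, so no step beyond the scatter is expected in this assay, though a shift either way remains possible. The expected result is no change at the digits printed from compound 2 to compound 3 (within the scatter). For compound 3 the estimated value is 15 nM, within an expected range of 5 nM to 50 nM.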

Compound 3, half-maximal inhibitory concentration: 15 nM
Estimate against measurement, compound 3: no gap at the digits printed; the measured number falls inside the stated range.
By their numbers in this assay, from the lowest: compounds 2 and 3 (each within the scatter of the next); then compound 1.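

Read in this assay, the result shows that this position does not respond to every change of group: no change at the digits printed from compound 2 to compound 3 (within the scatter) means that 4-fluorophenyl and 4-methylphenyl cannot be told apart here, although fluoro and methyl are different groups. Methyl also gives a 6.6-fold lower number from compound 1 to compound 3 (0.82 log units; beyond the scatter) and so matches the step already seen with fluoro, which leaves nitro as the one group of the three that stands apart, with the higher number and therefore the weaker inhibition. That is a comparison of three compounds and not a rule for the position, and nothing available here explains why the numbers fall this way.

The compounds shown leave open whether other groups at the same place, such as an amine, a carboxylic acid or a longer chain like propyl, would stay with fluoro and methyl or move toward nitro. They also leave open whether methyl and fluoro would remain this close on a different part of the shared core or in a different kind of cell.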